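From Compound 3 to Compound 4: an Ethoxyphenyl Estimate

A few compounds are considered here, and "the series" means these few. Any claim that something is new, unique, unknown or untested is made for them only; others in the source may bear on it.

Measured in an assay on mitochondria from L6 cells (Rattus norvegicus) for activation, with a stated time of 90 min; a higher number here means that more compound is needed for the effect, a lower number that less compound is needed:
compound 1, `Fc1ccccc1Nc1nc2nonc2nc1NC1CCCCC1`, gives 13400 nM
compound 2, `Cc1ccccc1Nc1nc2nonc2nc1Nc1ccccc1F`, gives 1100 nM
compound 3, `COc1cccc(Nc2nc3nonc3nc2Nc2ccccc2F)c1`, gives 830 nM
compound 4, `CCOc1ccc(Nc2nc3nonc3nc2Nc2ccccc2F)cc1`, is not yet measured.

Compound 3 has the lowest number of the three. Its nearest neighbour is compound 2, with a 1.3-fold lower number from compound 2 to compound 3 (0.12 log units; within the scatter), which lies within the scatter, so the two cannot be ordered. The furthest is compound 1, with a 16-fold lower number from compound 1 to compound 3 (1.21 log units; beyond the scatter). Compound 4 differs from compound 3 by 4-ethoxyphenyl in place of 3-methoxyphenyl on a nitrogen on an aromatic ring. The step that bears most directly on this change is the exchange of one aromatic ring for another, a 1.3-fold lower number from compound 2 to compound 3 (0.12 log units; within the scatter), which stayed within the scatter; the large steps of a 12-fold lower number from compound 1 to compound 2 (1.09 log units; beyond the scatter) and a 16-fold lower number from compound 1 to compound 3 (1.21 log units; beyond the scatter) concern the replacement of cyclohexyl by an aromatic ring and do not apply here. Compound 4 is therefore expected to show no step beyond the scatter, a 1.1-fold higher number from compound 3 to compound 4 (0.04 log units; within the scatter). The estimated value of compound 4 is 900 nM, with a range from 350 nM to 2500 nM.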

Compound 4, half-maximal effective concentration: 3800 nM
Compound 4: the middle estimate sits 4.2-fold (0.63 log units) below what was measured; the measured number lies above the stated range.
By their numbers in this assay, from the lowest: compounds 3 and 2 (each within the scatter of the next); then compound 4; then compound 1.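

In this assay, exchanging one aromatic group for another on this nitrogen now gives a step beyond the scatter (a 4.6-fold higher number from compound 3 to compound 4 (0.66 log units; beyond the scatter)), which the exchange between compound 2 and compound 3 did not. Compound 4 also stands apart from the 2-methylphenyl compound (a 3.5-fold higher number from compound 2 to compound 4 (0.54 log units; beyond the scatter)), yet it stays on the lower side of the cyclohexyl compound (a 3.5-fold lower number from compound 1 to compound 4 (0.55 log units; beyond the scatter)). Aromatic groups at this position are therefore not interchangeable.

From the compounds shown here alone, compound 4 changes both the place and the length of the ether group, so these two changes cannot be separated, and what a longer chain or an amine there would give stays open. No measurement at hand accounts for this step.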